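Hydroxyethyl in place of the pyrazolyl on the amide nitrogen

A few compounds are considered here, and "the series" means these few. Any claim that something is new, unique, unknown or untested is made for them only; others in the source may bear on it.

Measured so far:
- compound 1, `CCN(Cc1cccs1)C(=O)COc1ccc(C(=O)O)cc1`: "not active" (no number reported)
- compound 2, `Cc1ccc(OCC(=O)N(Cc2cccs2)c2c[nH]nc2C)cc1`: 0.4 nM
- compound 3, `O=C(COc1ccc2c(c1)CCC2)N(Cc1cccs1)c1ccn[nH]1`: 0.001 nM

In an assay on HEK293 cells for agonist activity at transient receptor potential cation channel subfamily M member 8 (Homo sapiens), read by fluorescence and calcium flux, with a stated time of 15 min (on this read-out lower numbers stand for an effect already at smaller amounts and higher numbers for an effect only at larger amounts of compound), compound 2 stands at the higher of the two reported numbers; compound 3 gives a lower one, and the gap between them lies beyond the scatter. Compound 1 is recorded as not active with no number, so it cannot be placed against the others. Compound 2 and compound 3 differ in several places at once, so the two values say only that both heteroaryl-bearing amides are potent in this assay.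

Compound 4, `Cc1ccc(OCC(=O)N(CCO)Cc2cccs2)cc1`, is yet to be measured. It differs from compound 2 in one place: 2-hydroxyethyl in place of 3-methyl-1H-pyrazol-4-yl on an amide-type nitrogen. The aryl ether side of the molecule stays as in compound 2.

For the measured compounds named here, no pair differing in one place has been measured, so the size of this step is open. Going by the values given here, compound 1, the only compound carrying a small saturated chain on that nitrogen, is reported as "not active" (no number reported), though it also differs elsewhere from compound 2. On that basis compound 4 is expected to give a markedly higher number than compound 2, with the step of a 130-fold higher number from compound 2 to compound 4 (2.10 log units; beyond the scatter) estimated to be beyond the scatter. For compound 4 the estimate is 50 nM, within 3 nM to 1000 nM.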

Compound 4, half-maximal effective concentration: 900 nM
For compound 4 the middle estimate is 18-fold (1.26 log units) below the measured one; measured number inside the range.
By their numbers in this assay, from the lowest: compound 3; then compound 2; then compound 4.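

In this assay the amide-type nitrogen can now be read through a single change, and 2-hydroxyethyl in place of 3-methyl-1H-pyrazol-4-yl gives a 2300-fold higher number from compound 2 to compound 4 (3.35 log units; beyond the scatter) as the step, so the number at this position depends strongly on the group it carries, although compound 4 still gives a measurable 900 nM in this series. The two groups have the same counts of hydrogen-bond donors and acceptors and no net charge, so matching those counts does not keep the number near that of compound 2; what separates them under this comparison is the five-membered aromatic ring and six heavy atoms against an open chain of three. Nothing on hand gives a reason for the size of this step.

For the compounds shown here, the single step changes ring and chain together, so it remains open whether the loss follows from removing the aromatic ring or from the hydroxyl-bearing chain that enters. A phenyl group, a 2-methoxyethyl chain or a 2-aminoethyl chain on the same nitrogen would show how much of the step each of these parts carries.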